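Ring size at the amidine of a diaryl sulfide

A few compounds are considered here, and "the series" means these few. Any claim that something is new, unique, unknown or untested is made for them only; others in the source may bear on it.

Measured so far:
compound 1 `COc1ccc(Sc2ccc(NC3=NCCN3)cc2)cc1`, 50.1 nM; 50.1 nM (2 entries)
compound 2 `COc1ccc(Sc2ccc(NC3=NC(C)(C)CN3)cc2)cc1`, 631 nM

In an assay (Rattus norvegicus) for binding affinity to prostacyclin receptor (Homo sapiens), read by radioligand binding (a lower number here means a stronger inhibitor, a higher number a weaker inhibitor), compound 1 gives 50.1 nM; 50.1 nM (2 entries), while compound 2 gives 631 nM, the weaker of the two numbers shown. Compound 3 `COc1ccc(Sc2ccc(NC3=NCCCCN3)cc2)cc1` differs from compound 2 in one place: a group of 7 heavy atoms (5 carbon, 2 nitrogen; one seven-membered non-aromatic ring with 2 hetero atoms) in place of a group of 7 heavy atoms (5 carbon, 2 nitrogen; one five-membered non-aromatic ring with 2 hetero atoms), on a nitrogen on an aromatic ring, on a nitrogen on an aromatic ring. Within the data shown here, no measured step of this kind exists here, so the direction of the change in this assay is open. Compound 3 is expected to land between the two numbers seen, at 200 nM, within 40 nM to 1000 nM, a step of a 3.2-fold lower number from compound 2 to compound 3 (0.50 log units; beyond the scatter).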

Compound 3, inhibition constant: 1260 nM
Estimate against measurement, compound 3: 6.3-fold (0.80 log units) below; measured number above the stated range.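

In this assay, a seven-membered non-aromatic ring with 2 hetero atoms in place of the five-membered one, on a nitrogen on an aromatic ring, gives a 2.0-fold higher number from compound 2 to compound 3 (0.30 log units; within the scatter), so this change does not separate the two rings beyond the scatter. The numbers of both still stand above that of compound 1, at 50.1 nM; 50.1 nM (2 entries). Nothing measured here speaks to the reason for this result.

Where a six-membered non-aromatic ring with 2 hetero atoms would fall at this nitrogen remains open. So does whether an open-chain guanidine would keep the number of compound 1.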